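Second Chloro Group on the Phenoxy Ring: Expected Cytotoxicity

The source may hold more compounds than are shown below. What is called first, only, known or untested is meant among the compounds shown, and "the series" means these compounds.

Compound 1 `NC(=S)N/N=C(/COc1ccc(Br)cc1)c1ccccc1` was tested in an ADME assay on L929 cells (Mus musculus) for cytotoxicity, read by resazurin assay, with a stated time of 96 h; on this read-out lower numbers stand for higher toxicity in this test and higher numbers for lower toxicity in this test; its result, < 27500 nM, is a limit of the assay. Compound 2 `NC(=S)N/N=C(/COc1ccc(Br)cc1)c1ccc(Cl)cc1` carries chloro in place of hydrogen on an aromatic carbon and gives 25100 nM in this assay. The step that the limit leaves unreadable from compound 1 to compound 2 cannot be read because of the limit of < 27500 nM in this assay, at which 1 of the 3 values shown sits. Compound 3 `NC(=S)N/N=C(\COc1ccc(Cl)cc1)c1ccc(Br)cc1` gives < 25100 nM in this assay, again a limit. The difference between the cores of compound 1 and compound 3 is not broken down here. Compound 4 `NC(=S)N/N=C(\COc1ccc(Cl)c(Cl)c1)c1ccc(Br)cc1` differs from compound 3 by chloro in place of hydrogen on an aromatic carbon, the same kind of change as that from compound 1 to compound 2, though here the entering chloro sits ortho to a chloro group and meta to a large group, whereas there it sat para to a large group. For the measured compounds named here, with the one measured step of this kind unreadable, the expected step is a step that the limit leaves unreadable from compound 3 to compound 4, kept small. Compound 4 is estimated at 18000 nM in this assay, expected between 7000 nM and 40000 nM.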

Compound 4, half-maximal cytotoxic concentration: 23100 nM
The estimate for compound 4 lay 1.3-fold (0.11 log units) below the measured number, and the stated range covers the measured number.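

No step can be read from compound 3 to compound 4, because compound 3 stands only as a limit: the limit of < 25100 nM in this assay, at which 1 of the 4 values shown sits. The compounds shown leave open whether chloro in place of hydrogen on an aromatic carbon changes the result in this assay at all.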